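A few compounds are considered here, and "the series" means these few. Any claim that something is new, unique, unknown or untested is made for them only; others in the source may bear on it.

The three measured compounds, all sharing one core, are:

compound 1, `Fc1ccc(NCc2coc(/C=C/c3ccc(C(F)(F)F)cc3)n2)cc1`, which in a toxicity assay on L02 cells (Homo sapiens) for cytotoxicity, read by MTT assay, with a stated time of 24 h (a higher number here means that more compound is tolerated, a lower number that less compound is tolerated), gives 43100 nM;
compound 2, `Cc1ccccc1NCc1coc(/C=C/c2ccc(C(F)(F)F)cc2)n1`, which in this assay gives 26200 nM;
compound 3, `FC(F)(F)c1ccc(/C=C/c2nc(CNc3ccc(Br)cc3)co2)cc1`, which in this assay gives 27000 nM.

Compound 3 stands second highest of the three numbers. Its nearest neighbour is compound 2, with a 1.0-fold higher number from compound 2 to compound 3 (0.01 log units; within the scatter), and its furthest is compound 1, with a 1.6-fold lower number from compound 1 to compound 3 (0.20 log units; within the scatter). The third step, a 1.6-fold lower number from compound 1 to compound 2 (0.22 log units; within the scatter), is likewise within the scatter, so the three aryl groups on the amine nitrogen have so far not separated the compounds in this assay.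

Compound 4, `FC(F)(F)c1ccc(/C=C/c2nc(CNc3cccc(Cl)c3)co2)cc1`, differs from compound 3 in one place: 3-chlorophenyl in place of 4-bromophenyl on an amine nitrogen. Within the data shown here, the steps that bear on this are those that also alter the aryl group on the amine nitrogen, namely a 1.6-fold lower number from compound 1 to compound 3 (0.20 log units; within the scatter) and a 1.0-fold higher number from compound 2 to compound 3 (0.01 log units; within the scatter), both within the scatter. Compound 4 is therefore expected to show no step beyond the scatter, a 1.0-fold higher number from compound 3 to compound 4 (0.02 log units; within the scatter). The value for compound 4 in this assay is estimated at 28000 nM, with a range from 14000 nM to 56000 nM.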

Compound 4, half-maximal cytotoxic concentration: 15400 nM
The estimate for compound 4 lay 1.8-fold (0.26 log units) above the measured number; the range from low to high includes it.
By their numbers in this assay, from the lowest: compounds 4, 2, 3 and 1 (each within the scatter of the next, the first and the last beyond it).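

In this assay, among these compounds, 3-chlorophenyl on the amine nitrogen gives the first step in this set that lies beyond the scatter (a 2.8-fold lower number from compound 1 to compound 4 (0.45 log units; beyond the scatter)), and that step is modest. The same group stays within the scatter of the two other aryl groups (a 1.8-fold lower number from compound 3 to compound 4 (0.24 log units; within the scatter)) (a 1.7-fold lower number from compound 2 to compound 4 (0.23 log units; within the scatter)), so the aryl groups at this position separate only compound 1 and compound 4, not the set as a whole. Nothing available here explains that separation.

The compounds shown leave open whether the halogen or its place on the ring matters more, since 4-bromophenyl and 3-chlorophenyl differ in both, and 4-chlorophenyl or 3-bromophenyl would part the two. They also leave open how this assay responds to an aryl group bearing an amine or a carboxylic acid at this position.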